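The source may hold more compounds than are shown below. What is called first, only, known or untested is meant among the compounds shown, and "the series" means these compounds.

In a functional assay on A549 cells (Homo sapiens) for inhibition, read by CCK-8 assay, with a stated time of 72 h, tested at 10 uM (a lower number here means a weaker effect, a higher number a stronger effect of the compound at the concentration tested), compound 3 `CN(C)C(=O)c1cc2cnc(Nc3ccc(C(=O)NCCCCCN=C=S)cc3)nc2n1C1CCCC1` gives 100%. Compound 1 `CN(C)C(=O)c1cc2cnc(Nc3ccc(S(=O)(=O)NCCCCN=C=S)cc3)nc2n1C1CCCC1` gives 101% in this assay, and compound 2 `CN(C)C(=O)c1cc2cnc(Nc3ccc(C(=O)NCCCCN=C=S)cc3)nc2n1C1CCCC1` gives 102%. All three numbers lie within the scatter of one another: a number 1 percentage points lower from compound 1 to compound 3 (within the scatter) and a number 2 percentage points lower from compound 2 to compound 3 (within the scatter), so compound 3 stands level with both of its neighbours at the top of the measured scale.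

Compound 4 `CN(C)C(=O)c1cc2cnc(Nc3ccc(C(=O)NCCCCCCN=C=S)cc3)nc2n1C1CCCC1` differs from compound 3 in one place: a group of 4 heavy atoms (2 carbon, 1 nitrogen, 1 sulfur; no ring) in place of a group of 3 heavy atoms (1 carbon, 1 nitrogen, 1 sulfur; no ring), on a saturated chain carbon, five bonds along the chain from an amide-type nitrogen. Among the measured compounds shown here, the one measured step that bears on this change is the step from compound 2 to compound 3, which lengthened the same chain by one carbon at the position four bonds along from the amide-type nitrogen, and that step came out as a number 2 percentage points lower from compound 2 to compound 3 (within the scatter). For the measured compounds named here, the single other measured steps, from compound 1 to compound 2 and from compound 1 to compound 3, exchange a different group and also stay within the scatter. Going by the values given here, with only one comparable step and no movement beyond the scatter in it, no change beyond the scatter is expected in this assay from compound 3 to compound 4, which means an expected step of no change at the digits printed from compound 3 to compound 4 (within the scatter). Compound 4 is therefore estimated to give 100% in this assay, with an expected range from 92% to 106%.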

Compound 4, a percentage reported as inhibition, at one concentration (the size of the read-out at that concentration, not a potency): 100%
For compound 4 middle estimate and measured number coincide at the digits printed, and the stated range covers the measured number.
By their numbers in this assay, from the lowest: compounds 3, 4, 1 and 2 (each within the scatter of the next).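

In this assay, a further carbon on the chain, five bonds along the chain from an amide-type nitrogen, gives no change at the digits printed from compound 3 to compound 4 (within the scatter), so this position now tolerates a second extension without any reading beyond the scatter. Taken together, the two extensions give a number 2 percentage points lower from compound 2 to compound 4 (within the scatter), and the exchange of the whole side group from the sulfonamide-linked compound gives a number 1 percentage points lower from compound 1 to compound 4 (within the scatter), so neither the longer chain nor this larger replacement separates the compounds at this concentration. Nothing shown here offers a reason for this flat result.

On these data alone, all four readings come from one concentration and are not potencies, so any differences among the compounds at lower concentrations remain unknown. Also open, as far as these compounds go, is whether an amine or a carboxylic acid at the chain end, in place of the group of 1 carbon, 1 nitrogen and 1 sulfur, or a much longer chain, would keep the same reading.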